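Trimming the propargyl arm on a selenium-bearing quinoline pair

This account rests on a few compounds, and the source may have more. Where it says the series, first, only, none or still open, it means among the compounds named here.

Compound 1 `C#CCSc1cnc2ccccc2c1[Se]CC#CCCl` holds the lowest number of the two measured compounds. In a functional assay on T47D cells (Homo sapiens) for antiproliferative activity, with a stated time of 72 h (on this read-out lower numbers stand for stronger inhibition and higher numbers for weaker inhibition), compound 1 gives 0.4 ug/mL, while compound 2 `CSc1cnc2ccccc2c1SCC#CCOC(=O)/C=C/c1ccccc1` gives 71.9 ug/mL, a gap far beyond the usual scatter. Compound 3 `CSc1cnc2ccccc2c1[Se]CC#CCCl` has not yet been measured; it differs from compound 1 by hydrogen in place of ethynyl on a saturated chain carbon bound to a sulfur, that is, propargylsulfanyl becomes methylsulfanyl. Compound 2 also carries methylsulfanyl, but it differs in several further places, so its value cannot be tied to this one change. A modest step from compound 1 to compound 3 is expected, a 2.0-fold higher number from compound 1 to compound 3 (0.30 log units; within the scatter), toward a somewhat weaker read-out. Compound 3 is estimated at 0.8 ug/mL, likely between 0.2 ug/mL and 3 ug/mL.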

Compound 3, concentration for 50% inhibition: 0.7 ug/mL
Compound 3: middle estimate off by 1.1-fold (0.06 log units), on the high side, and the stated range covers the measured number.
By their numbers in this assay, from the lowest: compounds 1 and 3 (each within the scatter of the next); then compound 2.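

Swapping propargylsulfanyl for methylsulfanyl gives a 1.8-fold higher number from compound 1 to compound 3 (0.24 log units; within the scatter) in this assay. At this position, then, the ethynyl end of the arm is not needed to hold the read-out at the level of compound 1, and the smaller methyl group serves as well. No measured evidence bears on why this is so.

From the compounds shown here alone, a longer chain such as butyl, or a carboxylic acid, on this sulfur remains untested here. Going by these compounds, the selenium and the chlorine-bearing arm also remain open, since compound 2 differs in several places at once.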